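From benzyl to 3-bromophenyl on the amide

A few compounds are considered here, and "the series" means these few. Any claim that something is new, unique, unknown or untested is made for them only; others in the source may bear on it.

Measured in a functional assay on HCT-116 cells (Homo sapiens) for antiproliferative activity, read by MTT assay, with a stated time of 72 h; on this read-out higher numbers stand for weaker inhibition and lower numbers for stronger inhibition:
compound 1 `O=C(CCc1cccc2c1B(O)OC2)NCc1ccccc1` (> 100000 nM)
compound 2 `CC(C)(C)c1ccc(NC(=O)CCc2cccc3c2B(O)OC3)cc1` (19000 nM)
compound 3 `CCOC(=O)c1ccc(NC(=O)CCc2cccc3c2B(O)OC3)cc1` (> 100000 nM)

Compound 1 gives > 100000 nM, which is a limit of the assay and not a number. Compound 3 also reports only a limit, and together they make up (the limit of > 100000 nM in this assay, at which 2 of the 3 values shown sit), so compound 1 offers no exact starting point. Compound 4 `O=C(CCc1cccc2c1B(O)OC2)Nc1cccc(Br)c1` has 3-bromophenyl in place of benzyl on an amide-type nitrogen. Going by the values given here, the one measured step that bears on this is an at least 5.2-fold higher number from compound 2 to compound 3 (0.72 log units; beyond the scatter), which lies beyond the scatter and shows that the group on the aromatic carbon matters in this assay. Among the compounds with values here, compound 2, at 19000 nM, is the only measured compound with a number. A modest move toward stronger inhibition is therefore expected, though compound 4 may stay at the limit. The expected step is an at least 2.2-fold lower number from compound 1 to compound 4 (0.34 log units; beyond the scatter), and its size stays uncertain. For compound 4 the estimated value is 45000 nM, with an expected range from 15000 nM to 100000 nM in this read-out.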

Compound 4, half-maximal inhibitory concentration: 1400 nM
Compound 4: middle estimate off by 32-fold (1.51 log units), on the high side, outside the stated range (below it).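

With 3-bromophenyl in place of benzyl on an amide-type nitrogen, this assay shows an at least 71-fold lower number from compound 1 to compound 4 (1.85 log units; beyond the scatter). The earlier step concerned only a group on an aromatic carbon, whereas this one shows that the group on the amide-type nitrogen also matters, and that this single change is enough to move the series from a limit to a measured number. The size of the step has only a lower bound, since compound 1 stands at a limit and not at a number: the limit of > 100000 nM in this assay, at which 2 of the 4 values shown sit.

The change swaps the whole group, so the compounds shown do not separate the contribution of the bromine from that of losing the benzyl carbon. Plain phenyl, 3-chlorophenyl and 3-bromobenzyl on the same nitrogen would tell these apart, and would show whether the bromine itself is needed.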